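Benzoxazolone propanoic acids: removing the pyridinylmethyl group

The source may report more compounds than this note shows. Statements on the series, on what has been measured and on what is new or still open speak of the compounds shown alone.

Measured compounds in an assay on HEK293 cells for inhibition of kynurenine 3-monooxygenase (Homo sapiens), read by LC-MS, with a stated time of 20 h; a higher number here means a weaker inhibitor, a lower number a stronger inhibitor:
- compound 1 `COCCOc1cc2oc(=O)n(CCC(=O)O)c2cc1Cl`: 50100 nM
- compound 2 `O=C(O)CCn1c(=O)oc2cc(Cl)c(Cl)cc21`: 2000 nM
- compound 3 `O=C(O)CCn1c(=O)oc2cc(OCc3ccccn3)c(Cl)cc21`: 5010 nM

Compound 3 holds the second highest number of the three: the step from compound 2 is a 2.5-fold higher number from compound 2 to compound 3 (0.40 log units; beyond the scatter), and the step from compound 1 is a 10-fold lower number from compound 1 to compound 3 (1.00 log units; beyond the scatter).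

Compound 4 `COc1cc2oc(=O)n(CCC(=O)O)c2cc1Cl` differs from compound 3 by hydrogen in place of pyridin-2-yl on a saturated chain carbon bound to an oxygen on an aromatic ring. Going by the values given here, the step bearing on this is the one with the same group in the other direction, a 10-fold lower number from compound 1 to compound 3 (1.00 log units; beyond the scatter), where the pyridin-2-yl entered in place of methoxymethyl and the number fell. Its removal is therefore expected to raise the number in this assay, though the entering hydrogen and the methoxymethyl it once replaced are not the same, so a smaller step is estimated. Compound 4 is expected to give 20000 nM, within 6000 nM to 60000 nM, a step of a 4.0-fold higher number from compound 3 to compound 4 (0.60 log units; beyond the scatter).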

Compound 4, half-maximal inhibitory concentration: 5010 nM
Beside the measured number, compound 4's estimate is 4.0-fold (0.60 log units) above it; measured number outside the range, below it.
By their numbers in this assay, from the lowest: compound 2; then compounds 3 and 4 (each within the scatter of the next); then compound 1.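

In this assay, no change at the digits printed from compound 3 to compound 4 (within the scatter): on a saturated chain carbon bound to an oxygen on an aromatic ring, pyridin-2-yl and hydrogen cannot be told apart. The high number of compound 1 therefore tracks the methoxymethyl, since a 10-fold lower number from compound 1 to compound 4 (1.00 log units; beyond the scatter), while on the aromatic carbon a 2.5-fold higher number from compound 2 to compound 4 (0.40 log units; beyond the scatter). No measured evidence here explains these steps.

As far as these compounds go, whether an ethyl or a hydroxyl on that oxygen would match compound 4 remains open. So does whether an amine at the end of the 2-methoxyethoxy chain would match compound 1.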